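Cyano for iodo at the assay limit

The compounds below may be only part of what the source reports. "The series", "measured", "known", "first", "only" and "open" are said of these compounds alone.

compound 1 (`Nc1ncnc2c1c(F)cn2[C@@H]1C=C(CO)[C@@H](O)[C@H]1O`) gives > 300000 nM as a limit
compound 2 (`Nc1ncnc2c1c(I)cn2[C@@H]1C=C(CO)[C@@H](O)[C@H]1O`) gives > 300000 nM as a limit
compound 3 (`C#Cc1cn([C@@H]2C=C(CO)[C@@H](O)[C@H]2O)c2ncnc(N)c12`) gives > 300000 nM as a limit

Among the measured compounds shown here, in an ADME assay on HepG2 2.2.15 cells (Homo sapiens) for cytotoxicity, read by neutral red uptake, with a stated time of 24 h (on this read-out lower numbers stand for stronger inhibition and higher numbers for weaker inhibition), compound 2 stands at > 300000 nM as a limit, and no measured compound gives a number. Compound 4 (`N#Cc1cn([C@@H]2C=C(CO)[C@@H](O)[C@H]2O)c2ncnc(N)c12`) has cyano in place of iodo on an aromatic carbon. The closest measured change is ethynyl in place of iodo, a step that the two limits leave unreadable from compound 2 to compound 3 and the step that the two limits leave unreadable from compound 1 to compound 2 is no more readable. Resting on these steps and on the limit of > 300000 nM in this assay, at which 3 of the 3 values shown sit, no step beyond the scatter is expected in this assay in either direction. The expected step is a number no higher from compound 2 to compound 4 (the limit leaves the size open) as estimated here. Compound 4 is estimated at 300000 nM with an expected range from 150000 nM to 600000 nM and will most likely be reported as a limit.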

Compound 4, half-maximal inhibitory concentration: > 300000 nM
Compound 4 ended at the assay's limit; the forecaster's own chance of this, stated with the estimate: 85%; the middle value lies on the limit itself.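

In this assay, among the compounds shown here, compound 4 joins compound 1, compound 2 and compound 3 as a limit, and no step among them can be read: the limit of > 300000 nM in this assay, at which 4 of the 4 values shown sit.

The compounds shown leave open how these four would rank against each other in this assay, as none of them gives a number.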